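The compounds below may be only part of what the source reports. "The series", "measured", "known", "first", "only" and "open" are said of these compounds alone.

Measured compounds:
- compound 1, `COc1cc(/C=C2\CCC/C(=C\c3ccc([N+](=O)[O-])cc3)C2=O)ccc1O`: 3400 nM
- compound 2, `COc1cc(/C=C2/C(=O)/C(=C/c3ccc([N+](=O)[O-])cc3)c3ccccc32)cc(OC)c1OC`: 318000 nM
- compound 3, `O=C1/C(=C/c2ccc(O)cc2)Cc2ccccc2/C1=C\c1ccc([N+](=O)[O-])cc1`: 2500 nM

All three compounds were tested in a functional assay on HL-60 cells (Homo sapiens) for cytotoxicity; a higher number here means that more compound is tolerated, a lower number that less compound is tolerated. Compound 1 gives 3400 nM in this assay. Compound 3 gives 2500 nM, and its number and that of compound 1 lie within the usual scatter of each other, so the two cannot be told apart. Compound 2 gives 318000 nM, a higher number than that of compound 1 by a margin that goes well beyond the scatter, so more of compound 2 is tolerated by the cells than of compound 1. Compound 1 thus sits at the less tolerated end of the three numbers, close to compound 3.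

The next compound, compound 4, `COc1ccc(/C=C2\CCC/C(=C\c3ccc([N+](=O)[O-])cc3)C2=O)cc1`, has not yet been measured. It differs from compound 1 in one place: 4-methoxyphenyl in place of 4-hydroxy-3-methoxyphenyl on a double-bonded chain carbon bound to a double-bonded ring carbon. Within the data shown here, no measured pair shows this particular change, so there is no direct guide to its effect. With only a hydroxyl group removed from one aryl ring, the step is expected to stay small, with no clear direction, and most likely within the scatter. Compound 4 is therefore expected to give about 4000 nM in this assay, between 1200 nM and 13000 nM, a step from compound 1 to compound 4 of a 1.2-fold higher number from compound 1 to compound 4 (0.07 log units; within the scatter) that is estimated rather than known.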

Compound 4, half-maximal cytotoxic concentration: > 400000 nM
Compound 4: a limit, no number; the forecaster's own chance of this, stated with the estimate: 5%; middle value at least 100-fold (2.00 log units) from the limit.
By their numbers in this assay, from the lowest: compounds 3 and 1 (each within the scatter of the next); then compound 2. At a limit, above all of these: compound 4.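

In this assay, compound 4 gives only a limit of the assay, > 400000 nM, and not a number. Among these compounds, the single change of 4-methoxyphenyl in place of 4-hydroxy-3-methoxyphenyl on a double-bonded chain carbon bound to a double-bonded ring carbon brings an at least 110-fold higher number from compound 1 to compound 4 (2.07 log units; beyond the scatter), so this position, on which no earlier pair could speak, has a large bearing on how much compound the cells tolerate. The step is a lower bound, and its full size cannot be read: the limit of > 400000 nM in this assay, at which 1 of the 4 values shown sits.

As far as these compounds go, what remains open is whether another group in place of the hydroxyl, such as an amine or a carboxylic acid, would keep the number close to that of compound 1. Also open, from the compounds shown here alone, is whether the same change on a different core would bring a step of similar size.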